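The source may hold more compounds than are shown below. What is called first, only, known or untested is meant among the compounds shown, and "the series" means these compounds.

Compounds measured in a functional assay on A498 cells (Homo sapiens) for cytotoxicity, read by sulforhodamine B assay, with a stated time of 48 h, tested at 0.1 uM; on this read-out lower numbers stand for a stronger effect and higher numbers for a weaker effect at the one concentration tested:
compound 1 `COc1ccc(-c2cc(/C=C/C(=O)c3ccc(N)cc3)[nH]n2)cc1`: 97%
compound 2 `COc1cc(-c2cc(/C=C/C(=O)c3ccc(Cl)c(Cl)c3)[nH]n2)cc(OC)c1OC`: 89%

In this assay compound 2 gives 89%, while compound 1 gives 97%; the two numbers lie within the scatter of each other, so compound 2 stands alongside compound 1 rather than apart from it. Compound 3 `COc1ccc(C(=O)/C=C/c2cc(-c3cc(OC)c(OC)c(OC)c3)n[nH]2)cc1` has not yet been measured. It differs from compound 2 in one place: 4-methoxyphenyl in place of 3,4-dichlorophenyl on a carbonyl carbon. Going by the values given here, no step between measured compounds is available to lean on, so the expected step, a number 3 percentage points higher from compound 2 to compound 3 (within the scatter), is none beyond the scatter. Compound 3 is therefore estimated at 92%, with a range from 80% to 104%.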

Compound 3, a percentage reported as activity, at one concentration (the size of the read-out at that concentration, not a potency): 87%
Estimate against measurement, compound 3: 5 percentage points above; measured number inside the range.
By their numbers in this assay, from the lowest: compounds 3, 2 and 1 (each within the scatter of the next).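

In this assay, going by these compounds alone, 4-methoxyphenyl in place of 3,4-dichlorophenyl on a carbonyl carbon gives a number 2 percentage points lower from compound 2 to compound 3 (within the scatter) and so offers the first comparison here of compounds differing in one place. At this position, one substituted phenyl group thus stands in for the other with no change that can be read at the single concentration tested. No available evidence bears on this result. From the compounds shown here alone, whether a carboxylic acid or a plain methyl group on that carbonyl carbon would move the read-out beyond the scatter remains open, as does whether these two groups would also match at other concentrations.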